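Moving the carboxy group back: an expected return of activity

A few compounds are considered here, and "the series" means these few. Any claim that something is new, unique, unknown or untested is made for them only; others in the source may bear on it.

Three compounds with a shared core were measured in an assay on HEK293 cells for positive allosteric modulation of metabotropic glutamate receptor 3 (Rattus norvegicus), read by thallium flux, with a stated time of 2.5 min; on this read-out higher numbers stand for an effect only at larger amounts of compound and lower numbers for an effect already at smaller amounts. Compound 1 `Cc1cc(C(=O)O)ccc1OCCCCOc1ccc(C(=O)CC(C)C)c(O)c1C` gives 1850 nM in this assay. Compound 2 `Cc1c(OCCCCOc2ccc(C(=O)O)cc2)ccc(C(=O)CC(C)C)c1O` gives 2720 nM, and the change between them, a 1.5-fold higher number from compound 1 to compound 2 (0.17 log units; within the scatter), is small. Compound 3 `Cc1ccc(C(=O)O)cc1OCCCCOc1ccc(C(=O)CC(C)C)c(O)c1C` reaches only the limit of this assay, > 10000 nM, so it stands at the weak end of the numbers shown; the step of an at least 5.4-fold higher number from compound 1 to compound 3 (0.73 log units; beyond the scatter) and the step of an at least 3.6-fold higher number from compound 2 to compound 3 (0.56 log units; beyond the scatter) both run beyond the scatter, and the evidence for this is the limit of > 10000 nM in this assay, at which 1 of the 3 values shown sits.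

Compound 4 `Cc1cc(OCCCCOc2ccc(C(=O)CC(C)C)c(O)c2C)ccc1C(=O)O` has not been measured. It differs from compound 3 by 4-carboxy-3-methylphenyl in place of 5-carboxy-2-methylphenyl on an oxygen on a saturated carbon. The group that enters carries its carboxy at position 4 of the phenyl ring, as the groups of compound 1 and compound 2 do, whereas the group that leaves carries it at position 5. Since both measured steps toward the 5-carboxy arrangement went to the limit of the assay, the reverse move is expected to bring the number back toward those of compounds 1 and 2. The expected step is an at least 3.3-fold lower number from compound 3 to compound 4 (0.52 log units; beyond the scatter) for compound 4. Compound 4 is therefore estimated at 3000 nM in this assay, within a range from 1200 nM to 8000 nM.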

Compound 4, half-maximal effective concentration: 3910 nM
The estimate for compound 4 lay 1.3-fold (0.12 log units) below the measured number; measured number inside the range.
By their numbers in this assay, from the lowest: compounds 1, 2 and 4 (each within the scatter of the next, the first and the last beyond it). At a limit, above all of these: compound 3.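

In this assay, the new group has the same atoms as the one it replaces, joined differently, yet the change from 5-carboxy-2-methylphenyl to 4-carboxy-3-methylphenyl brings a measurable number back (an at least 2.5-fold lower number from compound 3 to compound 4 (0.40 log units; beyond the scatter)), and because compound 3 stands at a limit, that step gives only a bound on the true size: the limit of > 10000 nM in this assay, at which 1 of the 4 values shown sits. Compound 4 also shows that adding methyl to the 4-carboxyphenyl group of compound 2 makes no difference that can be read (a 1.4-fold higher number from compound 2 to compound 4 (0.16 log units; within the scatter)), whereas the earlier compounds had shown this only for a methyl elsewhere on the shared core. Moving the methyl while the carboxy stays at position 4 has a modest effect (a 2.1-fold higher number from compound 1 to compound 4 (0.33 log units; beyond the scatter)), so among these compounds the one with its carboxy at position 5 is the only one at the limit, with none going against this.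

The compounds shown leave open whether the carboxylic acid itself is needed, as no methyl ester or primary amide stands in its place. They also leave open how a longer chain in place of the saturated chain would read out, or whether any other ring position would be tolerated.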